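Swapping Chloro for Trifluoromethyl on the Biaryl Tail

The source may hold more compounds than are shown below. What is called first, only, known or untested is meant among the compounds shown, and "the series" means these compounds.

Of the compounds shown here, two have so far been measured in a functional assay on cells for positive allosteric modulation of metabotropic glutamate receptor 2 (Homo sapiens), read by fluorescence and calcium flux, with a stated time of 30 min; on this read-out higher numbers stand for an effect only at larger amounts of compound and lower numbers for an effect already at smaller amounts. Compound 1 `Fc1cc(C(F)(F)F)ccc1-c1ccc(Cn2nnc3ccccc32)cc1` gives 29 nM in this assay. Compound 2 `Clc1ccc(-c2ccc(Cn3nnc4ccccc43)cc2)c(Cl)c1` gives 79 nM in this assay, the highest of the two numbers; compound 1 is its nearest neighbour, and the gap between the two lies beyond the usual scatter. Compound 3 `FC(F)(F)c1ccc(-c2ccc(Cn3nnc4ccccc43)cc2)c(Cl)c1` has not yet been measured. It differs from compound 2 by trifluoromethyl in place of chloro on an aromatic carbon. Among the measured compounds shown here, no step between measured compounds matches this change, so the comparison rests on compound 1, which also carries a trifluoromethyl group and gives 29 nM, set against compound 2 with 79 nM. On that basis a moderate step towards a lower number is expected for compound 3 in this assay, though a result within the scatter of compound 2 would not be surprising. Compound 3 is expected to give 40 nM in this assay, somewhere between 15 nM and 110 nM, which corresponds to an estimated step of a 2.0-fold lower number from compound 2 to compound 3 (0.30 log units; within the scatter).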

Compound 3, half-maximal effective concentration: 37 nM
Estimate against measurement, compound 3: 1.1-fold (0.03 log units) above; the measured number falls inside the stated range.
By their numbers in this assay, from the lowest: compounds 1 and 3 (each within the scatter of the next); then compound 2.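

In this assay, among the compounds shown here, trifluoromethyl in place of chloro on the aromatic carbon para to a large group and meta to a chloro group gives a 2.1-fold lower number from compound 2 to compound 3 (0.33 log units; beyond the scatter), the first direct reading of a change at this position; the step is modest but lies beyond the scatter. The second change, chloro in place of fluoro on an aromatic carbon with the trifluoromethyl group held constant, gives a 1.3-fold higher number from compound 1 to compound 3 (0.11 log units; within the scatter), so in this pair the read-out does not separate the two halogens. No measurement on hand accounts for either step.

The compounds shown carry only chloro, fluoro and trifluoromethyl on the biaryl tail, so it remains open how an amine, a carboxylic acid, a nitrile or a methoxy group would behave at the position para to a large group. As far as these compounds go, it is also open whether trifluoromethyl in place of chloro would give a step of similar size with fluoro rather than chloro as its partner group, and how any change to the shared core would read in this assay.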